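Swapping furan for thiophene on a hydrazone-linked thiazole

A few compounds are considered here, and "the series" means these few. Any claim that something is new, unique, unknown or untested is made for them only; others in the source may bear on it.

Measured so far:
- compound 1 `Fc1ccc(-c2csc(N/N=C\c3ccco3)n2)cc1` gives 40%
- compound 2 `Fc1ccc(-c2csc(N/N=C\c3cccs3)n2)cc1` gives 40%
- compound 3 `C/C(=N/Nc1nc(-c2ccc(F)cc2F)cs1)c1ccco1` gives 40%

All three values come from an in vitro assay on BTI-TN-5B1-4 cells for inhibition of Amine oxidase [flavin-containing] A (Homo sapiens), read by Amplex Red, with a stated time of 15 min, tested at 100 uM; a higher number here means more inhibition at the concentration tested (going by the name of the read-out), a lower number less inhibition. Compound 1 and compound 2 differ by one change, (thiophen-2-yl in place of furan-2-yl on a carbon with a double bond to nitrogen), and the step of no change at the digits printed from compound 1 to compound 2 (within the scatter) shows that this swap left the read-out unchanged. Compound 3 carries a different core; how its core differs from that of compound 1 is not broken down here, and compound 3 sits level with both in this assay.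

Compound 4 `C/C(=N/Nc1nc(-c2ccc(F)cc2F)cs1)c1cccs1` has not yet been measured. It differs from compound 3 by thiophen-2-yl in place of furan-2-yl on a carbon with a double bond to nitrogen. Within the data shown here, this is the same kind of change as the one from compound 1 to compound 2, not the same: around the carbon with a double bond to nitrogen, compound 3 also has a saturated chain carbon as a neighbour, which compound 1 does not. Because no change at the digits printed from compound 1 to compound 2 (within the scatter) was flat, the step of no change at the digits printed from compound 3 to compound 4 (within the scatter) is expected to be flat as well. Compound 4 is thus estimated at 40%, between 28% and 52%.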

Compound 4, a percentage reported as inhibition, at one concentration (the size of the read-out at that concentration, not a potency): 40%
Estimate against measurement, compound 4: no gap at the digits printed; the measured number falls inside the stated range.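

In this assay the swap of furan-2-yl for thiophen-2-yl gives no change at the digits printed from compound 3 to compound 4 (within the scatter) and so matches the earlier step on the other core: the same change on two cores in this assay, no change at the digits printed (within the scatter) from compound 1 to compound 2 and no change at the digits printed (within the scatter) from compound 3 to compound 4, 0 percentage points apart, within the scatter of two such steps. On these two cores, then, the swap carries over without a visible effect on the read-out. All four compounds sit level at a single tested concentration, which is not a potency, so this does not show that the paired compounds match in potency or that the swap would stay flat on any other core.

The compounds shown leave open what a group of another kind, such as an amine or a carboxylic acid, would do in place of the five-membered ring. Also open, from the compounds shown here alone, is whether a longer chain in place of the saturated chain carbon would change the read-out.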